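Swapping the ester's cinnamoyl for a simple acetyl

The source may hold more compounds than are shown below. What is called first, only, known or untested is meant among the compounds shown, and "the series" means these compounds.

Of the compounds shown here, two measured so far share one core: compound 1, `Cc1ccc(C(=O)OC2(C(=O)Nc3ccc([N+](=O)[O-])cc3)CCCCC2)cc1`, and compound 2, `O=C(/C=C/c1ccccc1)OC1(C(=O)Nc2ccc([N+](=O)[O-])cc2)CCCCC1`. In an ADME assay on WI-38 cells (Homo sapiens) for inhibition, read by MTT assay, with a stated time of 72 h (a lower number here means a stronger inhibitor, a higher number a weaker inhibitor), compound 1 gives 32 nM, and compound 2 gives 41 nM. Going by the values given here, compound 2 carries the highest of the two numbers, yet its only neighbour lies close: a 1.3-fold higher number from compound 1 to compound 2 (0.11 log units; within the scatter), a step too small to mean a real difference between the two.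

Compound 3, `CC(=O)OC1(C(=O)Nc2ccc([N+](=O)[O-])cc2)CCCCC1`, has not yet been measured. It differs from compound 2 in one place: methyl in place of 2-phenylethenyl on a carbonyl carbon. Among the compounds with values here, the one measured step that touches this position, a 1.3-fold higher number from compound 1 to compound 2 (0.11 log units; within the scatter), exchanged one eight-atom group for another of the same size and changed nothing beyond the scatter. Within the data shown here, no measured step shrinks this group to a single carbon, so the data give no direct guide; a loss of so much of the ester's substituent is expected to cost some inhibition, but with wide uncertainty. For compound 3 a weaker result is estimated, around 120 nM, between 40 nM and 400 nM, a step of a 2.9-fold higher number from compound 2 to compound 3 (0.47 log units; beyond the scatter).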

Compound 3, half-maximal inhibitory concentration: 386 nM
For compound 3 the middle estimate is 3.2-fold (0.51 log units) below the measured one, within the range that was stated.
By their numbers in this assay, from the lowest: compounds 1 and 2 (each within the scatter of the next); then compound 3.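

Going by these compounds alone, until now this position had seen only one large group exchanged for another, with no real change in this assay. Cutting the group on this carbonyl carbon down to methyl gives a different picture, with a 9.4-fold higher number from compound 2 to compound 3 (0.97 log units; beyond the scatter) and a 12-fold higher number from compound 1 to compound 3 (1.08 log units; beyond the scatter) on the same kind of change, so both steps lie beyond the scatter and mean weaker inhibition: the position does respond to what it carries, even though 2-phenylethenyl and 4-methylphenyl could stand in for each other. No measurement at hand explains why the number rises when the larger group leaves.

From the compounds shown here alone, what remains open is which part of the larger groups matters, since 2-phenylethenyl and methyl differ at once in the count of heavy atoms, in the aromatic ring and in the double bond, so the step cannot be split among them. A longer chain such as butyl or a cyclohexyl ring, each without an aromatic ring, would help to separate size from the ring itself, and a phenyl group joined directly to the carbonyl carbon, without the methyl of compound 1, would show how much that smaller ring alone keeps.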